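The source may report more compounds than this note shows. Statements on the series, on what has been measured and on what is new or still open speak of the compounds shown alone.

Compound 1, `COc1cc2c(cc1OC)C(=O)/C(=C/c1cccc(O)c1)CO2`, in an assay on isolated protein for inhibition of Amine oxidase [flavin-containing] B (Homo sapiens), read by fluorescence, with a stated time of 30 min; on this read-out lower numbers stand for stronger inhibition and higher numbers for weaker inhibition: 190 nM
Compound 2, `COc1cc2c(cc1OC)C(=O)/C(=C/c1ccc(CN3CCCCC3)c(O)c1)CO2`: 1740 nM

Among the compounds with values here, of the two measured compounds, compound 2 gives the higher number, so it is the weaker inhibitor; its only neighbour is compound 1, and the gap is a 9.2-fold higher number from compound 1 to compound 2 (0.96 log units; beyond the scatter), which came with (piperidin-1-yl)methyl in place of hydrogen on an aromatic carbon. Compound 3, `COc1cc2c(cc1OC)C(=O)/C(=C/c1ccc(CN(C)Cc3ccccc3)c(O)c1)CO2`, has not been measured. It differs from compound 2 by benzyl(methyl)amino in place of piperidin-1-yl on a saturated chain carbon bound to an aromatic carbon. Within the data shown here, the one measured step, a 9.2-fold higher number from compound 1 to compound 2 (0.96 log units; beyond the scatter), concerns adding the whole amine-bearing arm rather than exchanging its end, so it bears on compound 3 only loosely: compound 3 keeps such an arm and changes only what sits on its nitrogen. Among the measured compounds shown here, no measured pair shows what that exchange does. The expected change from compound 2 to compound 3 is therefore a 1.1-fold higher number from compound 2 to compound 3 (0.06 log units; within the scatter), not beyond the scatter in either direction. Compound 3 is estimated at 2000 nM, within 700 nM to 6000 nM.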

Compound 3, half-maximal inhibitory concentration: 1150 nM
Compound 3: middle estimate off by 1.7-fold (0.24 log units), on the high side; the measured number falls inside the stated range.
By their numbers in this assay, from the lowest: compound 1; then compounds 3 and 2 (each within the scatter of the next).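

In this assay, opening the piperidin-1-yl ring into benzyl(methyl)amino, which adds heavy atoms and brings in an aromatic ring, gives a 1.5-fold lower number from compound 2 to compound 3 (0.18 log units; within the scatter), so this exchange at the saturated chain carbon has no readable effect on the number. The cost of the arm remains with this second end, at a 6.1-fold higher number from compound 1 to compound 3 (0.78 log units; beyond the scatter), so across these three compounds the loss goes with having an amine-bearing arm on the aromatic carbon rather than with which of these two amines ends it. Nothing measured here explains why the arm raises the number.

Going by these compounds, both ends are tertiary amines carrying only carbon groups, so it remains open how the number would respond to a morpholine ring or a dimethylamino group at this place. An arm ending in a carboxylic acid, with no amine at all, could show whether any end brings the number back toward that of compound 1.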